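Working notes on the step from compound 1 to compound 4

The source may report more compounds than this note shows. Statements on the series, on what has been measured and on what is new or still open speak of the compounds shown alone.

Measured compounds:
compound 1 `Cc1c(-c2cc(Cl)cc(Cl)c2)c(C(=O)O)nn1-c1nc(-c2cc(Cl)cc(Cl)c2)c(SC(C)C)s1` — 2000 nM
compound 2 `COc1cc(-c2c(C)nn(-c3nc(-c4ccc(Cl)c(Cl)c4)c(SC(C)C)s3)c2C(=O)O)cc(C(F)(F)F)c1` — 1380 nM
compound 3 `Cc1nn(-c2nc(-c3ccc(Cl)c(Cl)c3)c(SC(C)C)s2)c(C(=O)O)c1-c1ccccc1C(F)(F)F` — 5200 nM

The read-out is a functional assay on BJAB cells (Homo sapiens) for antiproliferative activity, with a stated time of 4 days; a higher number here means that more compound is needed for the effect, a lower number that less compound is needed. Compound 1 gives 2000 nM, the second highest of the three numbers. Its nearest neighbour is compound 2, whose number lies within the scatter of that of compound 1; compound 3 stands furthest away, with a number beyond the scatter above that of compound 1.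

Compound 4 `Cc1oncc1-c1nc(-n2nc(C(=O)O)c(-c3cc(Cl)cc(Cl)c3)c2C)sc1SC(C)C` has not been measured. It differs from compound 1 in one place: 5-methyl-1,2-oxazol-4-yl in place of 3,5-dichlorophenyl on an aromatic carbon. Going by the values given here, the only measured step in the set, a 3.8-fold higher number from compound 2 to compound 3 (0.58 log units; beyond the scatter), concerns the aromatic group on the other ring, not the position changed here, so no measured step bears directly on this change. That one step shows that swapping one aromatic group for another moves the number only modestly. For compound 4 the step of a 1.8-fold higher number from compound 1 to compound 4 (0.24 log units; within the scatter) is therefore expected to be small, most likely toward a higher number, though a step within the scatter cannot be excluded. In this assay compound 4 is estimated at 3500 nM, with a range from 1200 nM to 10000 nM.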

Compound 4, half-maximal effective concentration: > 44000 nM
Compound 4: a limit, no number; the forecaster's own chance of this, stated with the estimate: 10%; at least 12-fold (1.09 log units) between middle value and limit.
By their numbers in this assay, from the lowest: compounds 2 and 1 (each within the scatter of the next); then compound 3. At a limit, above all of these: compound 4.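

In this assay, going by these compounds alone, the aromatic carbon next to the ring nitrogen and next to the ring atom that bears an isopropylsulfanyl group proves far less forgiving than the earlier compounds suggested: 5-methyl-1,2-oxazol-4-yl in place of 3,5-dichlorophenyl gives an at least 22-fold higher number from compound 1 to compound 4 (1.34 log units; beyond the scatter). Within the data shown here, the only earlier step, on the other aromatic group, was much smaller, at a 3.8-fold higher number from compound 2 to compound 3 (0.58 log units; beyond the scatter), so a swap of one aromatic group for another cannot be treated as equivalent at both places. The result for compound 4 is a limit and not a number, so the step gives only a lower bound on the size of the change: the limit of > 44000 nM in this assay, at which 1 of the 4 values shown sits.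

The change replaces a six-membered aromatic ring of carbon only with a five-membered aromatic ring with 2 hetero atoms and also adds a methyl group, and this single step cannot separate these differences. From the compounds shown here alone, it also remains open whether an unsubstituted phenyl or a pyridin-3-yl at this position would give a number close to that of compound 1 or a limit like that of compound 4.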